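This account rests on a few compounds, and the source may have more. Where it says the series, first, only, none or still open, it means among the compounds named here.

Compound 1 `C[C@H](NC(=O)c1c(C(F)(F)F)nnn1Cc1ccc(C(F)(F)F)cc1)c1ccc(C(=O)O)cc1` gives 225 nM in a functional assay on CHO cells for antagonist activity at prostaglandin E2 receptor EP4 subtype (Homo sapiens), read by calcium flux, with a stated time of 15 min; a higher number here means a weaker inhibitor, a lower number a stronger inhibitor.
Compound 2 `C[C@H](NC(=O)c1c(C2CCC2)nnn1Cc1ccc(C(F)(F)F)cc1)c1ccc(C(=O)O)cc1` gives 75.3 nM in this assay.
Compound 3 `C[C@H](NC(=O)c1c(C2CCCC2)nnn1Cc1ccc(C(F)(F)F)cc1)c1ccc(C(=O)O)cc1` gives 65.1 nM in this assay.

Compound 3 has the lowest number of the three, with the step of a 3.5-fold lower number from compound 1 to compound 3 (0.54 log units; beyond the scatter) beyond the scatter, while the step of a 1.2-fold lower number from compound 2 to compound 3 (0.06 log units; within the scatter) stays within it, so compound 2 and compound 3 cannot be told apart. Compound 4 `C[C@H](NC(=O)c1c(C2=CCOCC2)nnn1Cc1ccc(C(F)(F)F)cc1)c1ccc(C(=O)O)cc1` differs from compound 3 in one place: a group of 6 heavy atoms (5 carbon, 1 oxygen; one six-membered non-aromatic ring with 1 hetero atom) in place of a group of 5 heavy atoms (5 carbon; one five-membered non-aromatic ring of carbon only), on an aromatic carbon. Among the compounds with values here, the steps that bear on this are a 3.0-fold lower number from compound 1 to compound 2 (0.48 log units; beyond the scatter) and a 3.5-fold lower number from compound 1 to compound 3 (0.54 log units; beyond the scatter), both modest, and a 1.2-fold lower number from compound 2 to compound 3 (0.06 log units; within the scatter), which shows that swapping one small ring for another changed little. A ring of similar size is expected to give a step of a 1.2-fold higher number from compound 3 to compound 4 (0.09 log units; within the scatter) in this assay, not beyond the scatter. Compound 4 is therefore estimated at 80 nM, within 35 nM to 180 nM.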

Compound 4, half-maximal inhibitory concentration: 119 nM
For compound 4 the middle estimate is 1.5-fold (0.17 log units) below the measured one; the range from low to high includes it.
By their numbers in this assay, from the lowest: compounds 3, 2, 4 and 1 (each within the scatter of the next, the first and the last beyond it).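

A ring with an oxygen and a double bond is accepted at this position with no step beyond the scatter, whether set against the cyclopentyl (a 1.8-fold higher number from compound 3 to compound 4 (0.26 log units; within the scatter)) or the cyclobutyl (a 1.6-fold higher number from compound 2 to compound 4 (0.20 log units; within the scatter)). Against trifluoromethyl the step also stays within the scatter (a 1.9-fold lower number from compound 1 to compound 4 (0.28 log units; within the scatter)), so compound 4 cannot be told apart from any of the other three compounds. No measurement offered here accounts for these numbers. On these data alone, what a piperidine ring or an open butyl chain would give at this place remains open.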